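A Mirror-Image Change at One Stereocentre

The source may report more compounds than this note shows. Statements on the series, on what has been measured and on what is new or still open speak of the compounds shown alone.

Two structures are in view. Compound 1, `C[C@H](NCCSCCC(N)C(=O)O)C(=O)O`, has no number: in an assay for inhibition of betaine--homocysteine S-methyltransferase 1 (Homo sapiens) (on this read-out higher numbers stand for weaker inhibition and lower numbers for stronger inhibition), compound 1 gives "not determined" (no result reported), no result having been obtained for it. For the measured compounds named here, compound 2, `CC(C)(CCSCC[C@@H](N)C(=O)O)CC(=O)O`, carries the only measured value and therefore stands alone on the scale; in this assay compound 2 gives 701 nM.

Compound 3, `CC(C)(CCSCC[C@H](N)C(=O)O)CC(=O)O`, is the next step. Its relation to compound 2 is a pure change of configuration: the two compounds have the same atoms and bonds and differ only in configuration as drawn: 1 of 1 stereo elements differ; a stereocentre at a saturated chain carbon is drawn R in compound 2 and S in compound 3. Nothing is added and nothing is removed; only the spatial arrangement at that one chain carbon is reversed.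

Going by the values given here, because no pair of measured compounds differs in a single place, there is no measured step to lean on, and a change of this sort can shift inhibition by more than the usual scatter in either direction or leave it essentially unchanged. With only compound 2 as anchor, the expectation is a step from compound 2 to compound 3 of about a 1.4-fold lower number from compound 2 to compound 3 (0.15 log units; within the scatter), which may fall inside the scatter. For compound 3 the estimated value in this assay is 500 nM, with a plausible range from 100 nM to 2500 nM.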

Compound 3, half-maximal inhibitory concentration: 64 nM
Estimate against measurement, compound 3: 7.8-fold (0.89 log units) above, outside the stated range (below it).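

Until now compound 2 stood alone, and a single number gives no hint of whether the configuration at this saturated chain carbon matters for inhibition. Redrawing that carbon from R to S gives an 11-fold lower number from compound 2 to compound 3 (1.04 log units; beyond the scatter) in this assay, so this stereocentre is a place where the spatial arrangement alone clearly changes the read-out, and within this pair the S form is the stronger inhibitor. The gap can be assigned to this one stereocentre and to no other change in the structure, because nothing else separates the pair: the fact that compounds 2 and 3 differ only in the configuration as drawn.

This is still one pair on one read-out, so it shows the size and direction of the change for this particular structure and cannot say why the S form does better. On these data alone, whether the S form would keep its advantage with a longer chain, or with a tetrazole in place of a carboxylic acid, remains open, as does whether the gap would stay this wide in such compounds.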